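Nitrophenyl for cinnamyl on two saturated ring carbons

This account rests on a few compounds, and the source may have more. Where it says the series, first, only, none or still open, it means among the compounds named here.

Of the compounds shown here, three have been tested in an ADME assay on Vero cells (Chlorocebus sabaeus) for cytotoxicity, read by sulforhodamine B assay, with a stated time of 3 days; on this read-out higher numbers stand for lower toxicity in this test and lower numbers for higher toxicity in this test. Compound 1 `CC1=C(C(=O)Nc2ccc(Cl)cc2)C(c2cccc([N+](=O)[O-])c2)C(C(=O)Nc2ccc(Cl)cc2)=C(C)N1` gives 26 ug/mL, compound 2 `CC1=C(C(=O)Nc2ccc(Cl)cc2)C(C/C=C/c2ccccc2)C(C(=O)Nc2ccc(Cl)cc2)=C(C)N1` gives 21 ug/mL, and compound 3 `COc1ccc(NC(=O)C2=C(C)NC(=O)NC2C/C=C/c2ccccc2)cc1` gives 15 ug/mL. The change 3-nitrophenyl in place of 3-phenylprop-2-en-1-yl on a saturated ring carbon made a 1.2-fold higher number from compound 2 to compound 1 (0.09 log units; within the scatter). How the core of compound 3 differs from the core of compound 2 is not broken down here. Compound 4 `COc1ccc(NC(=O)C2=C(C)NC(=O)NC2c2cccc([N+](=O)[O-])c2)cc1` carries the same kind of change relative to compound 3, namely (3-nitrophenyl in place of 3-phenylprop-2-en-1-yl on a saturated ring carbon); around the place, the ring of compound 3 holds two nitrogen and the carbon is next to the ring nitrogen and next to the ring atom that bears a large group, whereas in compound 2 it is next to two ring atoms that each bear a (4-chlorophenyl)carbamoyl group. Because a 1.2-fold higher number from compound 2 to compound 1 (0.09 log units; within the scatter) stayed within the scatter, for compound 4 the expected step is a 1.1-fold higher number from compound 3 to compound 4 (0.05 log units; within the scatter). Compound 4 is estimated at 17 ug/mL, most likely between 8 ug/mL and 35 ug/mL.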

Compound 4, half-maximal cytotoxic concentration: 64 ug/mL
Beside the measured number, compound 4's estimate is 3.8-fold (0.58 log units) below it; measured number above the stated range.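

In this assay the change to 3-nitrophenyl in place of 3-phenylprop-2-en-1-yl gave a 4.3-fold higher number from compound 3 to compound 4 (0.63 log units; beyond the scatter), and this step does not match the one seen on the other core: the same change on two cores in this assay, a 1.2-fold higher number (0.09 log units; within the scatter) from compound 2 to compound 1 and a 4.3-fold higher number (0.63 log units; beyond the scatter) from compound 3 to compound 4, 3.4-fold (0.54 log units) apart, beyond the scatter of two such steps. In these two pairs, then, the size of the change depended on the core, and the step on one core did not carry over to the other. The pairs do not show which feature of the cores is responsible, and two cores set no rule for the rest of the series.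

As far as these compounds go, it remains open whether a plain phenyl or an aminophenyl on the saturated ring carbon would follow compound 4 or compound 3. From the compounds shown here alone, it is also open how the change would behave on a ring with two nitrogen that carries a (4-chlorophenyl)carbamoyl group.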